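Halogen swap on the anilino aryl of the shared core

The source may report more compounds than this note shows. Statements on the series, on what has been measured and on what is new or still open speak of the compounds shown alone.

Measured so far:
compound 1 `CCOc1ccc(NC2=C(C(=O)c3ccccc3)C(c3ccc(Br)cc3)N(CCCn3ccnc3)C2=O)cc1` — 20200 nM
compound 2 `O=C(C1=C(Nc2ccc(F)cc2)C(=O)N(CCCn2ccnc2)C1c1ccc(Br)cc1)c1ccccc1` — 27400 nM

Both compounds were tested in a functional assay on A549 cells (Homo sapiens) for antiproliferative activity, read by MTT assay, with a stated time of 72 h; on this read-out higher numbers stand for weaker inhibition and lower numbers for stronger inhibition. Compound 1 gives 20200 nM and compound 2 gives 27400 nM. Among the compounds with values here, the one step between them, a 1.4-fold higher number from compound 1 to compound 2 (0.13 log units; within the scatter), places fluoro in place of ethoxy on an aromatic carbon; it is within the scatter, so the two values are not distinguished. Compound 2 thus stands at one end of the two numbers, but its gap to compound 1 is within the scatter.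

Compound 3 `O=C(C1=C(Nc2ccc(I)cc2)C(=O)N(CCCn2ccnc2)C1c1ccc(Br)cc1)c1ccccc1` differs from compound 2 by iodo in place of fluoro on an aromatic carbon. Within the data shown here, no measured step bears directly on this change; the only step available, a 1.4-fold higher number from compound 1 to compound 2 (0.13 log units; within the scatter), concerns a different substituent at the same position and was within the scatter. Nothing here therefore supports an expected shift in this assay beyond the scatter in either direction. For compound 3 the number is expected to lie close to that of compound 2, at 22000 nM with a range of 7000 nM to 65000 nM. The step this estimate means is a 1.2-fold lower number from compound 2 to compound 3 (0.10 log units; within the scatter), expected to stay within the scatter.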

Compound 3, half-maximal inhibitory concentration: 24500 nM
Compound 3: the middle estimate sits 1.1-fold (0.05 log units) below what was measured, and the stated range covers the measured number.
By their numbers in this assay, from the lowest: compounds 1, 3 and 2 (each within the scatter of the next).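

Working notes on the anilino aryl: in this assay, the change from (4-fluorophenyl)amino to (4-iodophenyl)amino gives a 1.1-fold lower number from compound 2 to compound 3 (0.05 log units; within the scatter), so fluoro and iodo are not distinguished at this place, para to a large group. Within the data shown here, the second comparison, a 1.2-fold higher number from compound 1 to compound 3 (0.08 log units; within the scatter), sets iodo against ethoxy and also stays within the scatter; with the earlier step, all three pairs among ethoxy, fluoro and iodo are now read, and none separates on this read-out, where previously only one pair could be compared. No supporting data bear on why these three groups read alike, and the flat result stands as an observation only.

Open is whether an amine or a carboxylic acid on this same aromatic carbon would give a step beyond the scatter, since all three compounds shown carry ethoxy or a halogen there. Also open, going by these compounds, is whether the same flat reading would hold with a nitrile in place of the bromo group elsewhere on the shared core.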